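The compounds below may be only part of what the source reports. "The series", "measured", "known", "first", "only" and "open" are said of these compounds alone.

Measured in an ADME assay on the whole organism (blood, Mus musculus, strain C57BL/6) for pharmacokinetics, read by HPLC, with a stated time of 4 h, at a dose of 2 mg/kg by the intraperitoneal route; on this read-out lower numbers stand for lower exposure and higher numbers for higher exposure at the dose given:
- compound 1 `CC(C)S(=O)(=O)c1c(Cl)ccc(NC(=O)Nc2cccc(F)c2Cl)c1O`: 198 ng.h/mL
- compound 2 `CC(C)S(=O)(=O)c1c(Cl)ccc(NC(=O)Nc2cccc(Cl)c2Cl)c1O`: 290 ng.h/mL
- compound 3 `C[C@@H]1CN(S(=O)(=O)c2c(Cl)ccc(NC(=O)Nc3cccc(F)c3Cl)c2O)C[C@H](C)O1`: 279 ng.h/mL

The three values lie close together. Compound 2 is not separated from compound 1, as a 1.5-fold higher number from compound 1 to compound 2 (0.17 log units; within the scatter) shows, and its number nearly matches that of compound 3.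

Compound 4 `CCS(=O)(=O)c1c(Cl)ccc(NC(=O)Nc2cccc(Cl)c2Cl)c1O` differs from compound 2 at the sulfonyl group, isopropylsulfonyl to ethylsulfonyl: hydrogen in place of methyl on a saturated chain carbon bound to a saturated chain carbon and a sulfonyl sulfur. For the measured compounds named here, no ethyl compound has been measured. Going by the values given here, the only measured change on the sulfonyl sulfur, a 1.4-fold higher number from compound 1 to compound 3 (0.15 log units; within the scatter), stayed small, as did the chloro for fluoro change, so no step beyond the scatter is expected in this assay. The expected step is a 1.2-fold lower number from compound 2 to compound 4 (0.06 log units; within the scatter). Compound 4 is estimated at 250 ng.h/mL, with an expected range of 130 ng.h/mL to 480 ng.h/mL.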

Compound 4, area under the concentration-time curve: 256 ng.h/mL
Compound 4: middle estimate off by 1.0-fold (0.01 log units), on the low side, within the range that was stated.
By their numbers in this assay, from the lowest: compounds 1, 4, 3 and 2 (each within the scatter of the next).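

In this assay, hydrogen in place of methyl on a saturated chain carbon bound to a saturated chain carbon and a sulfonyl sulfur gave a 1.1-fold lower number from compound 2 to compound 4 (0.05 log units; within the scatter) and so left exposure unresolved from that of the isopropyl compound. Among the compounds shown, this is the only step that trims the group on the sulfonyl sulfur, and it shows that isopropyl to ethyl can be made here without a step beyond the scatter. No measurement given here explains this result. As far as these compounds go, whether a longer chain, an amine or a carboxylic acid at this place would also stay within the scatter remains open.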